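Replacing the Diol Side Chain in a Kinase Inhibitor Series

The source may report more compounds than this note shows. Statements on the series, on what has been measured and on what is new or still open speak of the compounds shown alone.

Measured compounds:
compound 1, `Cn1ncc(Cl)c1-c1cc(C(=O)N[C@@H]2CN[C@H](CC(O)CO)C[C@H]2c2ccc(Cl)c(Cl)c2)oc1Cl`, 3.79 nM
compound 2, `Cn1ncc(Cl)c1-c1cc(C(=O)N[C@@H]2CN[C@H](CCN3CCC(O)CC3)C[C@H]2c2ccc(Cl)c(Cl)c2)oc1Cl`, 5.99 nM
compound 3, `Cn1ncc(Cl)c1-c1cc(C(=O)N[C@@H]2CN[C@H](CCN3CCCC3)C[C@H]2c2ccc(Cl)c(Cl)c2)oc1Cl`, 6.41 nM

The three compounds share one core and differ only in the group carried on a saturated chain carbon bound to a saturated ring carbon. In an assay for inhibition of RAC-alpha serine/threonine-protein kinase (Homo sapiens), read by HTRF, with a stated time of 1 h (a lower number here means a stronger inhibitor, a higher number a weaker inhibitor), compound 1 gives the lowest of the three numbers, but its neighbours lie close: the step of a 1.6-fold higher number from compound 1 to compound 2 (0.20 log units; within the scatter) and the step of a 1.7-fold higher number from compound 1 to compound 3 (0.23 log units; within the scatter) are both within the scatter, as is the step of a 1.1-fold higher number from compound 2 to compound 3 (0.03 log units; within the scatter). On the numbers shown, nothing separates the three beyond measurement noise.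

Compound 4, `COCC[C@@H]1C[C@@H](c2ccc(Cl)c(Cl)c2)[C@H](NC(=O)c2cc(-c3c(Cl)cnn3C)c(Cl)o2)CN1`, has not yet been measured in this assay. It differs from compound 1 by methoxymethyl in place of 1,2-dihydroxyethyl on a saturated chain carbon bound to a saturated ring carbon. Going by the values given here, the steps that bear on it are those from compound 1 to compound 2 and from compound 1 to compound 3, in which the 1,2-dihydroxyethyl group was likewise exchanged, each time for a slightly higher number that stayed within the scatter. On that basis compound 4 is expected to show a step of a 1.5-fold higher number from compound 1 to compound 4 (0.16 log units; within the scatter), at most a modest rise and possibly none beyond the scatter. The estimate for compound 4 in this assay is 5.5 nM, with a range from 2.5 nM to 12 nM.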

Compound 4, half-maximal inhibitory concentration: 7.01 nM
Estimate against measurement, compound 4: 1.3-fold (0.11 log units) below; the measured number falls inside the stated range.
By their numbers in this assay, from the lowest: compounds 1, 2, 3 and 4 (each within the scatter of the next).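

In this assay the step of a 1.8-fold higher number from compound 1 to compound 4 (0.27 log units; within the scatter) shows that this position also accepts an open chain with no nitrogen and no hydrogen-bond donor: methoxymethyl enters with neither, while the 1,2-dihydroxyethyl group that leaves carries two donors and the groups of compound 2 and compound 3 each bring a nitrogen-containing ring. The step of a 1.1-fold higher number from compound 3 to compound 4 (0.04 log units; within the scatter) and the step of a 1.2-fold higher number from compound 2 to compound 4 (0.07 log units; within the scatter) likewise stay within the scatter, so among these four compounds no exchange at this place, whether to an ether, a pyrrolidine or a hydroxypiperidine, separates one number from another. No supporting measurement is available to explain this flat response.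

The compounds shown leave open whether any group at this place would move the number beyond the scatter, for example a carboxylic acid, a primary amine, a plain ethyl chain with no oxygen or a longer chain. They also leave open whether the same tolerance would hold on a core other than the shared one, or for a side chain carrying an aromatic ring.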